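The source may hold more compounds than are shown below. What is called first, only, known or untested is meant among the compounds shown, and "the series" means these compounds.

Working notes on the series. For the measured compounds named here, in a functional assay on CCRF-CEM cells for antagonist activity at C-X-C chemokine receptor type 4 (Homo sapiens), read by calcium flux, with stated times of 25 min and 90 s (a higher number here means a weaker inhibitor, a lower number a stronger inhibitor), compound 1 `CN(C[C@H]1Cc2c(cccc2N2CCN(Cc3ccccn3)CC2)CN1)[C@H]1CCCc2cccnc21` gives 4.47 nM, the lowest of the three numbers measured so far. Going by the values given here, compound 2 `CN(C[C@H]1Cc2c(cccc2N2C[C@@H]3C[C@H]2CN3)CN1)[C@H]1CCCc2cccnc21` gives 146 nM and compound 3 `CN(C[C@H]1Cc2c(cccc2N2C[C@H]3C[C@@H]2CN3)CN1)[C@H]1CCCc2cccnc21` gives 20.7 nM; the only step measured so far, a 7.1-fold lower number from compound 2 to compound 3 (0.85 log units; beyond the scatter), rests on the fact that compounds 2 and 3 differ only in the configuration as drawn and says nothing about the group on the ring nitrogen. Compound 4 `CN(C[C@H]1Cc2c(cccc2N2CCNCC2)CN1)[C@H]1CCCc2cccnc21` differs from compound 1 by hydrogen in place of (pyridin-2-yl)methyl on an amine nitrogen in a ring. Among the compounds with values here, no measured pair isolates this change; the nearest guide is that both compounds carrying a free ring amine hydrogen, compound 2 and compound 3, sit above compound 1. A weakening step is therefore expected for compound 4, of the size a 6.7-fold higher number from compound 1 to compound 4 (0.83 log units; beyond the scatter). The estimate for compound 4 in this assay is 30 nM, with a range from 8 nM to 120 nM.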

Compound 4, half-maximal inhibitory concentration: 6.08 nM
Compound 4: the middle estimate sits 4.9-fold (0.69 log units) above what was measured, and the stated range ends above it.
By their numbers in this assay, from the lowest: compounds 1 and 4 (each within the scatter of the next); then compound 3; then compound 2.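

In this assay, hydrogen in place of (pyridin-2-yl)methyl on the amine nitrogen in the ring stays within the scatter (a 1.4-fold higher number from compound 1 to compound 4 (0.13 log units; within the scatter)), so a free ring amine hydrogen does not by itself go with a higher number. The group on the aromatic carbon does count, with the six-membered ring with 2 nitrogen giving the lower number in both comparisons (a 3.4-fold lower number from compound 3 to compound 4 (0.53 log units; beyond the scatter)) and (a 24-fold lower number from compound 2 to compound 4 (1.38 log units; beyond the scatter)). These two steps differ in size, and their starting compounds are separated by configuration alone: the fact that compounds 2 and 3 differ only in the configuration as drawn.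

On these data alone, it remains open whether an acetyl group or a longer chain such as n-butyl on that nitrogen would also stay within the scatter of compound 4.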